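A few compounds are considered here, and "the series" means these few. Any claim that something is new, unique, unknown or untested is made for them only; others in the source may bear on it.

In an in vivo ADME assay on the whole organism (Cavia porcellus) (a lower number here means that the compound disappears faster, a higher number that the compound lasts longer), two compounds have been measured so far. Compound 1 `C/C=C/C(NC(=O)c1ccc(C(=N)N)cc1)C(C)(C)C(=O)N1CCC(CC(=O)O)CC1` gives 0.933 h, and compound 2 `CC(C)(C(=O)N1CCC(CC(=O)O)CC1)C(CCc1ccccc1)NC(=O)c1ccc(C(=N)N)cc1` gives 0.767 h. Compound 2 therefore stands level with compound 1, since their two values lie within the scatter of each other.

Compound 3 `CC(C)(C(=O)N1CCC(CC(=O)O)CC1)C(NC(=O)c1ccc(C(=N)N)cc1)c1ccc(O)cc1` has 4-hydroxyphenyl in place of phenethyl on a saturated chain carbon bound to an amide-type nitrogen and a saturated chain carbon.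

Within the data shown here, only one measured step bears on this change. It lies at the same place and brought in phenethyl in place of prop-1-en-1-yl: a 1.2-fold lower number from compound 1 to compound 2 (0.09 log units; within the scatter). Among the measured compounds shown here, no measured compound carries 4-hydroxyphenyl, so the data offer no direct precedent for this group and give no direction for the step. Going by the small size of that single step, no change beyond the scatter is expected in this assay, although one step is thin evidence.

The expected step is a 1.0-fold higher number from compound 2 to compound 3 (0.02 log units; within the scatter). For compound 3 the estimated half-life is 0.8 h, with an expected range from 0.4 h to 1.6 h.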

Compound 3, half-life: 1.05 h
Compound 3: middle estimate off by 1.3-fold (0.12 log units), on the low side, within the range that was stated.
By their numbers in this assay, from the lowest: compounds 2, 1 and 3 (each within the scatter of the next).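

In this assay, three different groups now stand on a saturated chain carbon bound to an amide-type nitrogen and a saturated chain carbon, and the half-life stays level across them (a 1.4-fold higher number from compound 2 to compound 3 (0.14 log units; within the scatter); a 1.1-fold higher number from compound 1 to compound 3 (0.05 log units; within the scatter)). The earlier pair covered only prop-1-en-1-yl and phenethyl, whereas this result extends the level picture to 4-hydroxyphenyl, a group with a hydrogen-bond donor and a hydrogen-bond acceptor where phenethyl has neither, and the half-life still moves no further than the scatter. No measurement here offers an account of why the half-life stays level at this position.

The step from phenethyl to 4-hydroxyphenyl alters the chain and adds the hydroxyl in a single move, so their separate contributions stay unresolved, and plain phenyl at the same place would be needed to pull them apart. On these data alone, it also remains open whether any group at this position can carry the half-life beyond the scatter, for instance an amine, a carboxylic acid or a longer chain.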